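The compounds below may be only part of what the source reports. "The series", "measured", "known", "first", "only" and "open" are said of these compounds alone.

Measured compounds:
compound 1 `CCC(=O)N1CCC(CN(C2Cc3cc(C#N)ccc3N(Cc3cncn3C)C2)S(=O)(=O)c2ccccn2)CC1`: 0.5 10^-6 cm/s
compound 2 `Cn1cncc1CN1CC(N(CC2CCN(S(C)(=O)=O)CC2)S(=O)(=O)c2ccccn2)Cc2cc(C#N)ccc21`: 0.1 10^-6 cm/s
compound 3 `Cn1cnc(S(=O)(=O)N(Cc2cccc(-n3cccc3)c2)C2Cc3cc(C#N)ccc3N(Cc3cncn3C)C2)c1`: 0.2 10^-6 cm/s

In an ADME assay on Caco-2 cells (Homo sapiens) for permeability, in the apical to basolateral direction (a lower number here means that the compound crosses the layer more slowly, a higher number that the compound crosses the layer faster), compound 2 stands below compound 1, the step being a 5.0-fold lower number from compound 1 to compound 2 (0.70 log units; beyond the scatter), while compound 3 sits within the scatter of compound 2. Compound 4 `CC(C)OC(=O)N1CCC(CN(C2Cc3cc(C#N)ccc3N(Cc3cncn3C)C2)S(=O)(=O)c2ccccn2)CC1` is not yet measured; it differs from compound 2 in one place, (isopropoxycarbonyl in place of methylsulfonyl on an amine nitrogen in a ring). For the measured compounds named here, the only measured step that bears on this change is the one from compound 1 to compound 2, where the same position carried propanoyl instead of methylsulfonyl and the number was higher by a 5.0-fold lower number from compound 1 to compound 2 (0.70 log units; beyond the scatter). Read backwards, that step suggests a modest rise when methylsulfonyl is removed. Compound 4 is therefore expected to give 0.6 10^-6 cm/s, in a range from 0.25 10^-6 cm/s to 1.5 10^-6 cm/s, an expected step of a 6.0-fold higher number from compound 2 to compound 4 (0.78 log units; beyond the scatter).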

Compound 4, apparent permeability: 1 10^-6 cm/s
Compound 4: the middle estimate sits 1.7-fold (0.22 log units) below what was measured; the measured number falls inside the stated range.
By their numbers in this assay, from the lowest: compounds 2 and 3 (each within the scatter of the next); then compounds 1 and 4 (each within the scatter of the next).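

Replacing methylsulfonyl with isopropoxycarbonyl on this amine nitrogen in the ring gives a 10-fold higher number from compound 2 to compound 4 (1.00 log units; beyond the scatter) in this assay and so shows a second carbonyl-bearing group standing clearly above the methylsulfonyl compound. Isopropoxy in place of ethyl on the carbonyl carbon gives a 2.0-fold higher number from compound 1 to compound 4 (0.30 log units; within the scatter) and does not separate the two carbonyl-bearing groups. No evidence is available to explain these differences. From the compounds shown here alone, it remains open whether a simple alkyl chain or a urea at this nitrogen would match the carbonyl-bearing groups or the methylsulfonyl group.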